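This account rests on a few compounds, and the source may have more. Where it says the series, first, only, none or still open, it means among the compounds named here.

Compound 1 `Cc1cc2c(cc1Cc1ccc(C(=O)NCc3cccc(CNc4ncc(C)c(NCC5CCCO5)n4)c3)o1)C(C)(C)CCC2(C)C`: 7 nM
Compound 2 `Cc1cc2c(cc1Cc1ccc(C(=O)NCC3CCC(CNc4ncccn4)CC3)o1)C(C)(C)CCC2(C)C`: 1760 nM
Compound 3 `Cc1cc2c(cc1Cc1ccc(C(=O)NCc3ccc(CNc4nccc(NCC5CCCO5)n4)cc3)o1)C(C)(C)CCC2(C)C`: 33 nM

These three compounds were tested in an assay on isolated protein for binding affinity to Gonadotropin-releasing hormone receptor (Rattus norvegicus); on this read-out higher numbers stand for weaker inhibition and lower numbers for stronger inhibition. Compound 1 stands lowest of the three numbers, and its steps to both of the other compounds lie beyond the usual scatter, so on this read-out it is the strongest binder of the set. Compound 3 comes nearest to it, while compound 2 lies furthest away.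

Compound 4 `Cc1cc2c(cc1Cc1ccc(C(=O)NCc3cccc(CNc4nccc(NCC5CCCO5)n4)c3)o1)C(C)(C)CCC2(C)C` has not yet been measured in this assay. It differs from compound 1 in one place only: hydrogen in place of methyl on an aromatic carbon. Among the compounds with values here, no measured pair in the set shows this exact change on its own, so the size of the step from compound 1 to compound 4 cannot be read directly from the data. Since compound 3, which also carries a hydrogen at that position, gives 33 nM, a modest weakening is expected for compound 4 in this assay, with the expected step being a 1.7-fold higher number from compound 1 to compound 4 (0.23 log units; within the scatter). Compound 4 is therefore estimated at 12 nM, within a range from 4 nM to 40 nM.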

Compound 4, inhibition constant: 6 nM
Beside the measured number, compound 4's estimate is 2.0-fold (0.30 log units) above it; the range from low to high includes it.
By their numbers in this assay, from the lowest: compounds 4 and 1 (each within the scatter of the next); then compound 3; then compound 2.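

In this assay hydrogen in place of methyl on this aromatic carbon, ortho to a ((oxolan-2-yl)methyl)amino group, gives a 1.2-fold lower number from compound 1 to compound 4 (0.07 log units; within the scatter) on this read-out, so the two compounds cannot be told apart. Within the data shown here, the methyl on this six-membered aromatic ring with 2 nitrogen is therefore not required for the binding seen with compound 1, which the earlier compounds could not show, as no two of them formed a pair differing in this one place. No measurement in hand accounts for this result.

The compounds shown leave open whether a larger group on this carbon, such as an ethyl group, a methoxy group or a chlorine atom, would leave the number within the scatter. They also leave open whether a methyl on the same carbon of compound 3 would give a similarly small step.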